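This account rests on a few compounds, and the source may have more. Where it says the series, first, only, none or still open, it means among the compounds named here.

In an ADME assay on CEMx174 cells (Homo sapiens) for cytotoxicity (on this read-out higher numbers stand for lower toxicity in this test and lower numbers for higher toxicity in this test), two compounds built on a shared core have been measured so far. Compound 1 `CCC1=C(C(=O)OCC2CCCCC2)C(c2ccc(NC)cc2)NC(=O)N1` gives > 10000 nM, which is a limit of the assay and not a number. Compound 2 `CCC1=C(C(=O)OCC2CCCCC2)C(c2ccc(C(=O)O)cc2)NC(=O)N1` gives > 10000 nM, which is likewise only a limit. The evidence so far is the limit of > 10000 nM in this assay, at which 2 of the 2 values shown sit. The next change leads to compound 3 `CCC1=C(C(=O)OCC2CCCCC2)C(c2ccc(Cl)cc2)NC(=O)N1`, and it is chloro in place of carboxy on an aromatic carbon. Within the data shown here, the only measured step that bears on it is a step that the two limits leave unreadable from compound 1 to compound 2, which also concerns the carboxy group on the aromatic carbon, and no size can be taken from it. Among the measured compounds shown here, with no sized step to carry over, no step beyond the scatter and no firm direction is expected in this assay. The estimated move is a step that the limit leaves unreadable from compound 2 to compound 3. For compound 3 the expected value is 15000 nM. The estimated range for compound 3 runs from 6000 nM to 30000 nM.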

Compound 3, half-maximal cytotoxic concentration: > 10000 nM
Compound 3 gave a limit, no number; the forecaster's own chance of this, stated with the estimate: 75%; the middle value does not contradict the limit.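

Compound 3 gives only a limit of the assay, as do compound 1 and compound 2, so no step among these three can be read in this assay. The compounds shown leave open whether carboxy, chloro or methylamino on the aromatic carbon makes any difference to the read-out: the limit of > 10000 nM in this assay, at which 3 of the 3 values shown sit.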